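The source may hold more compounds than are shown below. What is called first, only, known or untested is meant among the compounds shown, and "the series" means these compounds.

In a functional assay on NCI-H460 cells (Homo sapiens) for inhibition, read by sulforhodamine B assay, with a stated time of 48 h (a higher number here means a weaker inhibitor of growth, a lower number a stronger inhibitor of growth), compound 1 `COc1cccc(C(=O)NNC(=O)c2ccc3[nH]c(-c4ccc([N+](=O)[O-])o4)nc3c2)c1` gives 62.5 ug/mL. Compound 2 `O=CNNC(=O)c1ccc2[nH]c(-c3ccc([N+](=O)[O-])o3)nc2c1` gives 31.3 ug/mL, and these two values lie within the usual scatter of each other. Compound 3 `O=C(NNC(=O)c1ccc2[nH]c(-c3ccc([N+](=O)[O-])o3)nc2c1)c1cccc(Oc2ccccc2)c1` gives > 7.8 ug/mL, which is a limit and not a number. The comparison with compound 1 is therefore a step that the limit leaves unreadable from compound 1 to compound 3.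

The next compound, compound 4 `COc1cccc(C(=O)NNC(=O)c2ccc3[nH]c(-c4ccc([N+](=O)[O-])s4)nc3c2)c1`, keeps the rest of compound 1 but carries 5-nitrothiophen-2-yl in place of 5-nitrofuran-2-yl on an aromatic carbon. For the measured compounds named here, all three measured compounds carry the 5-nitrofuran-2-yl group, so no measured step tests this exchange directly. Going by the values given here, the only readable step changes another part of the molecule: putting hydrogen in place of 3-methoxyphenyl on a carbonyl carbon gives a 2.0-fold lower number from compound 1 to compound 2 (0.30 log units; within the scatter). That weak guide offers no reason to expect a real shift in either direction in this assay. The estimate is a 1.3-fold lower number from compound 1 to compound 4 (0.10 log units; within the scatter), which is expected to stay within the scatter. For compound 4 the expected value is 50 ug/mL, with an estimated range from 16 ug/mL to 125 ug/mL.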

Compound 4, concentration for 50% growth inhibition: 62.5 ug/mL
For compound 4 the middle estimate is 1.3-fold (0.10 log units) below the measured one; the range from low to high includes it.
By their numbers in this assay, from the lowest: compounds 2, 1 and 4 (each within the scatter of the next).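

This position now has its first measured exchange, on the aromatic carbon between two ring nitrogen atoms. In this assay, 5-nitrothiophen-2-yl in place of 5-nitrofuran-2-yl gives no change at the digits printed from compound 1 to compound 4 (within the scatter) and so, with the 3-methoxyphenyl end held fixed, this assay does not separate the two rings. Nothing measured here explains why the two groups read alike.

This single pair leaves open whether the same exchange would read alike with a different group at the other end of the molecule, such as the hydrogen of compound 2. On these data alone, how the position would respond to a ring that keeps no nitro group, such as plain phenyl, or to an amine in place of the nitro group on the furan ring also remains open.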